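A few compounds are considered here, and "the series" means these few. Any claim that something is new, unique, unknown or untested is made for them only; others in the source may bear on it.

The series shares a diaryl-bearing chain ending in a urea that carries a substituted phenyl ring. Compound 1 `O=C(NCCCCC(c1ccc(F)cc1)c1ccc(F)cc1)Nc1cccc(C(F)(F)F)c1` is the reference member; in a functional assay on MDA-MB-231 cells (Homo sapiens) for cytotoxicity, read by MTT assay, with a stated time of 48 h (a higher number here means a weaker inhibitor, a lower number a stronger inhibitor), compound 1 gives 3380 nM. Compound 2 `O=C(NCCCCC(c1ccc(F)cc1)c1ccc(F)cc1)Nc1cccc([N+](=O)[O-])c1` differs from compound 1 by nitro in place of trifluoromethyl on an aromatic carbon, and in this assay compound 2 gives 3790 nM; the step is a 1.1-fold higher number from compound 1 to compound 2 (0.05 log units; within the scatter). Compound 3 `O=C(NCCCCC(c1ccc(F)cc1)c1ccc(F)cc1)Nc1ccc(Cl)c(C(F)(F)F)c1` carries the core change (chloro in place of hydrogen on an aromatic carbon); in this assay compound 3 gives 3150 nM, and the step from compound 1 is a 1.1-fold lower number from compound 1 to compound 3 (0.03 log units; within the scatter). Compound 2 and compound 3 differ by a larger exchange, with a 1.2-fold lower number from compound 2 to compound 3 (0.08 log units; within the scatter). All three numbers lie within the usual scatter of one another, so no ordering among them can be read from the data.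

Compound 4 `O=C(NCCCCC(c1ccc(F)cc1)c1ccc(F)cc1)Nc1ccc(Cl)c([N+](=O)[O-])c1` is not yet measured. It differs from compound 3 by nitro in place of trifluoromethyl on an aromatic carbon. This is the same kind of change as the one from compound 1 to compound 2, the only other occurrence of it among these compounds; the surroundings are not identical, since in compound 3 the trifluoromethyl that leaves stands ortho to a chloro group (1 heavy atom) as well as meta to a large group, whereas in compound 1 it stands only meta to a large group. Because a 1.1-fold higher number from compound 1 to compound 2 (0.05 log units; within the scatter) was within the scatter, the expected step is a 1.1-fold higher number from compound 3 to compound 4 (0.05 log units; within the scatter), a step of similar size. Whether the chloro group alters the response cannot be told from these data. Compound 4 is expected to give 3500 nM in this assay, estimated to fall between 2000 nM and 6500 nM.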

Compound 4, half-maximal inhibitory concentration: 4060 nM
Compound 4: the middle estimate sits 1.2-fold (0.06 log units) below what was measured, within the range that was stated.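

Nitro in place of trifluoromethyl on the chloro-bearing core gives a 1.3-fold higher number from compound 3 to compound 4 (0.11 log units; within the scatter) in this assay, and this step matches the one on the core of compound 1: the same change on two cores in this assay, a 1.1-fold higher number (0.05 log units; within the scatter) from compound 1 to compound 2 and a 1.3-fold higher number (0.11 log units; within the scatter) from compound 3 to compound 4, 1.1-fold (0.06 log units) apart, within the scatter of two such steps. Chloro in place of hydrogen, carried onto the nitro-bearing core, gives a 1.1-fold higher number from compound 2 to compound 4 (0.03 log units; within the scatter), and this step likewise matches its earlier counterpart: the same change on two cores in this assay, a 1.1-fold lower number (0.03 log units; within the scatter) from compound 1 to compound 3 and a 1.1-fold higher number (0.03 log units; within the scatter) from compound 2 to compound 4, 1.1-fold (0.06 log units) apart, within the scatter of two such steps. Going by these compounds alone, the larger exchange gives a 1.2-fold higher number from compound 1 to compound 4 (0.08 log units; within the scatter), so neither single change reads differently on the two cores, but every step lies within the scatter, which shows only that these changes leave no measurable mark here, not that their contributions add up or that a change with a real effect would carry across in the same way.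

The compounds shown carry only trifluoromethyl, nitro and chloro on the phenyl ring of the urea, which leaves open whether an amine or a carboxylic acid on that ring would give a step beyond the scatter in this assay. On these data alone, whether a longer chain in the shared core would do so also remains open.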